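The source may hold more compounds than are shown below. What is called first, only, known or untested is meant among the compounds shown, and "the series" means these compounds.

In an ADME assay on microsomes from liver (Homo sapiens) for metabolic stability, read by LC-MS, tested at 0.5 uM (a lower number here means that the compound disappears faster, a higher number that the compound lasts longer), the measured compounds stand as follows.

Compound 1 `Cc1cc(CCOc2ccc(-c3c(C)nc(C)c([C@H](OC(C)(C)C)C(=O)O)c3N3CCC(C)(C)CC3)cc2)ccc1F` gives > 2 h, which is a limit of the assay.
Compound 2 `Cc1nc(C)c([C@H](OC(C)(C)C)C(=O)O)c(N2CCC(C)(C)CC2)c1-c1ccc(CCCc2ccc(F)cc2)cc1` gives > 2 h, which is a limit of the assay.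
Compound 3 `Cc1nc(C)c([C@H](OC(C)(C)C)C(=O)O)c(N2CCC(C)(C)CC2)c1-c1ccc(OC2COCC2c2ccc(F)cc2)cc1` gives 0.783 h.

Within the data shown here, compound 3 thus holds the only number among the three values shown; the other two fall under (the limit of > 2 h in this assay, at which 2 of the 3 values shown sit). The step from compound 1 to compound 3, which puts 4-(4-fluorophenyl)oxolan-3-yl in place of 2-(4-fluoro-3-methylphenyl)ethyl on an oxygen on an aromatic ring, reads an at least 2.5-fold lower number from compound 1 to compound 3 (0.40 log units; beyond the scatter). The step from compound 1 to compound 2 reads a step that the two limits leave unreadable from compound 1 to compound 2.

Compound 4 `Cc1nc(C)c(CCOc2ccc(-c3c(C)nc(C)c([C@H](OC(C)(C)C)C(=O)O)c3N3CCC(C)(C)CC3)cc2)s1` differs from compound 3 by 2-(2,4-dimethyl-1,3-thiazol-5-yl)ethyl in place of 4-(4-fluorophenyl)oxolan-3-yl on an oxygen on an aromatic ring. This change removes the group whose arrival in compound 3 went with the lower number and restores an ethyl link on that oxygen, as in the 2-(4-fluoro-3-methylphenyl)ethyl of compound 1, now carrying a 2,4-dimethyl-1,3-thiazol-5-yl rather than a fluorophenyl. Among the measured compounds shown here, no measured step covers a thiazole; the step from compound 1 to compound 3 is the only guide. Compound 4 is therefore expected to show a 2.0-fold higher number from compound 3 to compound 4 (0.31 log units; beyond the scatter) in this assay, moving back toward the limit. The estimated value for compound 4 is 1.6 h, within 0.8 h to 2 h, with a fair chance that only the limit is reported.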

Compound 4, half-life: 0.917 h
Compound 4: middle estimate off by 1.7-fold (0.24 log units), on the high side, and the stated range covers the measured number.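

In this assay, the exchange on the oxygen on an aromatic ring gives a 1.2-fold higher number from compound 3 to compound 4 (0.07 log units; within the scatter), so the 2-(2,4-dimethyl-1,3-thiazol-5-yl)ethyl and the 4-(4-fluorophenyl)oxolan-3-yl cannot be told apart here. The ethyl link on that oxygen does not by itself keep the number at the limit: with 2,4-dimethyl-1,3-thiazol-5-yl in place of 4-fluoro-3-methylphenyl on the saturated chain carbon, the result is an at least 2.1-fold lower number from compound 1 to compound 4 (0.33 log units; beyond the scatter). Setting 2-(2,4-dimethyl-1,3-thiazol-5-yl)ethoxy in place of 3-(4-fluorophenyl)propyl on the aromatic carbon likewise gives an at least 2.1-fold lower number from compound 2 to compound 4 (0.33 log units; beyond the scatter), and the true size of this step and the one before it stays unknown: the limit of > 2 h in this assay, at which 2 of the 4 values shown sit.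

On these data alone, whether the lower number follows the thiazole ring itself or its two methyl groups remains open, and a 1,3-thiazol-5-yl without methyl groups or a pyridine ring on the same ethyl link would be needed to separate the two in this assay. As far as these compounds go, it also remains open whether a fluorophenyl on that ethyl link without the methyl group of compound 1 would stay at the limit.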